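A few compounds are considered here, and "the series" means these few. Any claim that something is new, unique, unknown or untested is made for them only; others in the source may bear on it.

Of the compounds shown here, three built on a shared core have been tested in a functional assay on HT-29 cells (Homo sapiens) for cytotoxicity, read by sulforhodamine B assay; on this read-out lower numbers stand for stronger inhibition and higher numbers for weaker inhibition. Compound 1 `C=C1[C@@H](OC(C)=O)C[C@@H]2[C@](C)(COC=O)[C@H](OC(C)=O)CC[C@@]2(C)[C@@H]1C[C@@H](Nc1cccc(F)c1)C1=CCOC1=O` gives 9410 nM in this assay. Compound 3 `C=C1[C@@H](OC(C)=O)C[C@@H]2[C@](C)(CO[Si](C)(C)C(C)(C)C)[C@H](OC(C)=O)CC[C@@]2(C)[C@@H]1C[C@@H](Nc1cccc(F)c1)C1=CCOC1=O` differs from compound 1 in a single place: a group of 7 heavy atoms (6 carbon, 1 silicon; no ring) in place of a group of 2 heavy atoms (1 carbon, 1 oxygen; no ring), on an oxygen on a saturated carbon. In this assay compound 3 gives 4520 nM. In this assay that change produced a 2.1-fold lower number from compound 1 to compound 3 (0.32 log units; beyond the scatter).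

Compound 2 `C=C1[C@@H](OC(C)=O)C[C@@H]2[C@](C)(COC=O)[C@H](OC(C)=O)CC[C@@]2(C)[C@@H]1C/C=C1/C(=O)OC[C@H]1OC(C)=O` carries a different side group on the shared core; how the two cores of compound 1 and compound 2 differ is not broken down here. In this assay compound 2 gives 8290 nM, a number that lies within the usual scatter of the number for compound 1, so the two cannot be told apart on this read-out.

Compound 4 `C=C1[C@@H](OC(C)=O)C[C@@H]2[C@](C)(CO[Si](C)(C)C(C)(C)C)[C@H](OC(C)=O)CC[C@@]2(C)[C@@H]1C/C=C1/C(=O)OC[C@H]1OC(C)=O` has not been measured yet. It stands to compound 2 exactly as compound 3 stands to compound 1: a group of 7 heavy atoms (6 carbon, 1 silicon; no ring) in place of a group of 2 heavy atoms (1 carbon, 1 oxygen; no ring), on an oxygen on a saturated carbon. The surroundings of the place are the same in both pairs, so this is the same change made a second time, on the other core.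

The expectation for compound 4 rests on a single earlier pair. Because a 2.1-fold lower number from compound 1 to compound 3 (0.32 log units; beyond the scatter) was modest but beyond the scatter, the same change is expected to give a step of similar size, a 2.0-fold lower number from compound 2 to compound 4 (0.31 log units; beyond the scatter). Compound 4 is therefore expected to give about 4100 nM in this assay. Among the compounds with values here, the estimate for compound 4 is expected to fall between 2000 nM and 8500 nM, the width reflecting that only one prior instance of the change is available.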

Compound 4, half-maximal inhibitory concentration: 4940 nM
Compound 4: the middle estimate sits 1.2-fold (0.08 log units) below what was measured; the range from low to high includes it.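

In this assay, putting the group of 7 heavy atoms (6 carbon, 1 silicon) in place of formyl, on an oxygen on a saturated carbon, gives a 1.7-fold lower number from compound 2 to compound 4 (0.22 log units; within the scatter), a step that taken alone cannot be told apart from repeat-to-repeat variation. Set beside the earlier step, the change points the same way on both cores, and the two steps do not differ by more than the normal spread of such measurements: the same change on two cores in this assay, a 2.1-fold lower number (0.32 log units; beyond the scatter) from compound 1 to compound 3 and a 1.7-fold lower number (0.22 log units; within the scatter) from compound 2 to compound 4, 1.2-fold (0.09 log units) apart, within the scatter of two such steps. This fits the idea that the change carries from one core to the other in this small series, but two pairs are thin support: they do not establish a real shift on the core of compound 2, and they say nothing about why the numbers move or whether the same would hold on a third core.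

The compounds shown leave open what other groups on this same oxygen would do, for instance a free hydroxyl, a benzyl group or a longer carbon chain bearing an amine or a carboxylic acid. They also leave open whether a change of that kind would give a step large enough to stand clear of the scatter on both cores.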